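Cytotoxicity notes: trifluorophenyl swap in the acid series

This account rests on a few compounds, and the source may have more. Where it says the series, first, only, none or still open, it means among the compounds named here.

Going by the values given here, compound 2 `COc1cccc2c1c(C(=O)/C=C(\O)C(=O)O)cn2Cc1ccc(F)cc1` gives 41100 nM in an ADME assay on MT4 cells (Homo sapiens) for cytotoxicity, read by MTT assay (a lower number here means that less compound is tolerated, a higher number that more compound is tolerated), the higher of the two numbers measured so far; compound 1 `CCOC(=O)/C(O)=C/C(=O)c1cn(Cc2cc(F)c(F)c(F)c2)c2cccc(OC)c12` gives 33400 nM, and the two values lie within the scatter of each other. Compound 3 `COc1cccc2c1c(C(=O)/C=C(\O)C(=O)O)cn2Cc1cc(F)c(F)c(F)c1` differs from compound 2 by 3,4,5-trifluorophenyl in place of 4-fluorophenyl on a saturated chain carbon bound to an aromatic nitrogen. Among the compounds with values here, no measured pair isolates this change, so its size is unknown; compound 1 already carries the 3,4,5-trifluorophenyl group with a number close to that of compound 2. The step of a 1.1-fold lower number from compound 2 to compound 3 (0.06 log units; within the scatter) is therefore expected to stay within the scatter. Compound 3 is estimated at 36000 nM, with a range from 16000 nM to 80000 nM.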

Compound 3, half-maximal cytotoxic concentration: 23300 nM
Estimate against measurement, compound 3: 1.5-fold (0.19 log units) above; measured number inside the range.
By their numbers in this assay, from the lowest: compounds 3, 1 and 2 (each within the scatter of the next).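

In this assay the exchange of 4-fluorophenyl for 3,4,5-trifluorophenyl on a saturated chain carbon bound to an aromatic nitrogen now has a measured pair, and a 1.8-fold lower number from compound 2 to compound 3 (0.25 log units; within the scatter) stays within the scatter. Hydrogen in place of ethyl on an oxygen next to a carbonyl group also stays within the scatter, with a 1.4-fold lower number from compound 1 to compound 3 (0.16 log units; within the scatter) as its step. No measured evidence bears on either step. The compounds shown leave open how an unsubstituted phenyl or a longer chain at this place would read, and how an amide in place of the carboxylic acid would compare.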